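Compound 2 to compound 3: a side-chain change

The source may report more compounds than this note shows. Statements on the series, on what has been measured and on what is new or still open speak of the compounds shown alone.

Of the compounds shown here, two have been measured so far. In a functional assay on HL-60 cells (Homo sapiens) for inhibition, read by ATP content, with a stated time of 72 h (on this read-out lower numbers stand for stronger inhibition and higher numbers for weaker inhibition), compound 1 (`CCN(CC)c1ccc(NC(=O)CCCCCCC(=O)NO)cc1`) gives 2700 nM as a real number.

In this assay compound 2 (`CCC(CC)CCNC(=O)c1ccc(NC(=O)CCCCCCC(=O)NO)cc1`) gives > 10000 nM and this is only a limit, not a number. Compound 2 therefore stands at the limit of > 10000 nM in this assay, at which 1 of the 2 values shown sits, and has no exact position in the series.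

Compound 3 (`CCN(CC)CCCNC(=O)c1ccc(NC(=O)CCCCCCC(=O)NO)cc1`) is the next compound to be read. The change from compound 2 is (diethylamino)methyl in place of pentan-3-yl on a saturated chain carbon, two bonds along the chain from an amide-type nitrogen and in words it puts (diethylamino)methyl in place of pentan-3-yl on a saturated chain carbon, two bonds along the chain from an amide-type nitrogen.

Among the compounds with values here, no measured step covers this change, so the expectation is loose. A moderate move towards stronger inhibition is expected, which would bring the reading inside the measurable range, though another limit remains possible. Within the data shown here, the only anchor is compound 1 at 2700 nM on the same read-out. The expected step is an at least 2.0-fold lower number from compound 2 to compound 3 (0.30 log units; that floor lies within the scatter) in that direction.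

Compound 3 is estimated at 5000 nM in this assay with an expected range of 1500 nM to 15000 nM for repeat measurements.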

Compound 3, half-maximal inhibitory concentration: 34000 nM
For compound 3 the middle estimate is 6.8-fold (0.83 log units) below the measured one; measured number outside the range, above it.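

No step from compound 2 to compound 3 can be read, because compound 2 carries only a limit in this assay: the limit of > 10000 nM in this assay, at which 1 of the 3 values shown sits.

The compounds shown leave open both the direction and the size of the change in this assay when (diethylamino)methyl stands in place of pentan-3-yl.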